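One Carbon Longer: From Compound 2 to Compound 3

The source may report more compounds than this note shows. Statements on the series, on what has been measured and on what is new or still open speak of the compounds shown alone.

Compound 1, `Fc1ccc(C(c2ccc(F)cc2)N2CCC3(CCN(Cc4ccc(Cl)cc4)C3)CC2)cc1`: 66%
Compound 2, `COCCN1CCC2(CCN(C(c3ccc(F)cc3)c3ccc(F)cc3)CC2)C1=O`: 28%

Of the compounds shown here, two have been measured in a functional assay on cells for antagonist activity at Voltage-dependent T-type calcium channel subunit alpha-1H (Homo sapiens), read by patch clamp, tested at 1 uM; on this read-out higher numbers stand for more inhibition at the one concentration tested (going by the name of the read-out) and lower numbers for less inhibition. Compound 1 `Fc1ccc(C(c2ccc(F)cc2)N2CCC3(CCN(Cc4ccc(Cl)cc4)C3)CC2)cc1` gives 66%. Compound 2 `COCCN1CCC2(CCN(C(c3ccc(F)cc3)c3ccc(F)cc3)CC2)C1=O` gives 28%, the lowest of the two numbers; its nearest neighbour, compound 1, stands a good deal higher, a gap that lies beyond the scatter. The two differ in more than one place, so their gap cannot be read as a single step.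

Compound 3 `COCCCN1CCC2(CCN(C(c3ccc(F)cc3)c3ccc(F)cc3)CC2)C1=O` has not yet been measured. It differs from compound 2 in one place: methoxymethyl in place of methoxy on a saturated chain carbon, two bonds along the chain from an amide-type nitrogen in a ring. For the measured compounds named here, no step between measured compounds matches this change, so there is no direct precedent to lean on. A lengthening of the chain of this kind is expected to move the read-out little; the step of a number 2 percentage points higher from compound 2 to compound 3 (within the scatter) is expected to stay within the scatter, in either direction. Compound 3 is therefore estimated at 30%, with a range from 10% to 50%.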

Compound 3, a percentage reported as inhibition, at one concentration (the size of the read-out at that concentration, not a potency): 44%
Compound 3: middle estimate off by 14 percentage points, on the low side, within the range that was stated.
By their numbers in this assay, from the lowest: compound 2; then compound 3; then compound 1.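

In this assay, for the compounds shown here, the chain on the amide-type nitrogen in a ring proves able to move the read-out: the change from 2-methoxyethyl to 3-methoxypropyl gives a number 16 percentage points higher from compound 2 to compound 3 (beyond the scatter) at this position, the first single change that can be read. The step is modest, yet it lies beyond the scatter, so this change on the saturated chain carbon is not a silent one. Nothing available accounts for the step.

With a single step on this chain, the compounds shown leave open whether a still longer chain, such as 4-methoxybutyl, would continue the rise or reverse it. They also leave open whether the methoxy end itself matters, which a plain propyl chain, or one ending in a hydroxyl or an amine, would test.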